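Trimming the Benzyl Group on Sulfur to Methyl

The source may report more compounds than this note shows. Statements on the series, on what has been measured and on what is new or still open speak of the compounds shown alone.

Compound 2 `COC(=O)[C@H]1N=C(SCc2ccccc2)[C@H]2C(=O)N(c3ccccc3)C(=O)[C@H]21` gives 76% in a functional assay for inhibition, tested at 100 uM; on this read-out lower numbers stand for less inhibition and higher numbers for more inhibition at the one concentration tested (going by the name of the read-out); its nearest neighbour, compound 1 `CCCSC1=N[C@H](C(=O)OC)[C@@H]2C(=O)N(c3ccccc3)C(=O)[C@H]12`, gives 86%, and the step of a number 10 percentage points lower from compound 1 to compound 2 (within the scatter) stays within the scatter. Compound 3 `COC(=O)[C@H]1N=C(SC)[C@H]2C(=O)N(c3ccccc3)C(=O)[C@H]21` differs from compound 2 by hydrogen in place of phenyl on a saturated chain carbon bound to a sulfur. Within the data shown here, the only measured step touching this position, a number 10 percentage points lower from compound 1 to compound 2 (within the scatter), changed nothing beyond the scatter, so this further cut at the same carbon is expected to shift this assay little, with no clear direction. Compound 3 is therefore expected to give 78%, within a range from 58% to 95%. The expected step is a number 2 percentage points higher from compound 2 to compound 3 (within the scatter).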

Compound 3, a percentage reported as inhibition, at one concentration (the size of the read-out at that concentration, not a potency): 84%
Beside the measured number, compound 3's estimate is 6 percentage points below it; low and high end bracket the measured number.
By their numbers in this assay, from the lowest: compounds 2, 3 and 1 (each within the scatter of the next).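

With benzylsulfanyl cut back to methylsulfanyl, this assay shows a number 8 percentage points higher from compound 2 to compound 3 (within the scatter), and hydrogen in place of ethyl on the same carbon gives a number 2 percentage points lower from compound 1 to compound 3 (within the scatter). Across all three pairs, hydrogen, ethyl and phenyl on this saturated chain carbon bound to a sulfur leave the read-out within the scatter, so removing the chain's extra carbons altogether still preserves the inhibition seen at this concentration. No evidence here speaks to what lies behind this result. On these data alone, whether a carboxylic acid, an amine or a longer chain at this carbon would move the read-out beyond the scatter remains open. These single-concentration numbers also leave the potency of all three compounds unsettled.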